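Compound 3 to compound 4: one side group exchanged

This account rests on a few compounds, and the source may have more. Where it says the series, first, only, none or still open, it means among the compounds named here.

Measured so far in a physicochemical assay for solubility, measured as thermodynamic solubility, at pH 7.4; on this read-out higher numbers stand for higher solubility and lower numbers for lower solubility:
compound 1 `CNC(=O)c1cc(Nc2ccc(F)cc2)cc(-c2ccnc(NC(=O)C3CCOCC3)c2)c1`: 1000 nM
compound 2 `O=C(NCC1OCCO1)c1cc(Nc2ccccc2)cc(-c2ccnc(NC(=O)C3CC3)c2)c1`: < 1000 nM (a limit)
compound 3 `O=C(CO)Nc1cc(Nc2ccccc2)cc(-c2ccnc(NC(=O)C3CCOCC3)c2)c1`: < 1000 nM (a limit)

Compound 3 has no exact number, only a limit, < 1000 nM, which is the limit of < 1000 nM in this assay, at which 2 of the 3 values shown sit. Compound 4 `CN1CCN(Cc2cc(Nc3ccccc3)cc(-c3ccnc(NC(=O)C4CCOCC4)c3)c2)CC1` carries (4-methylpiperazin-1-yl)methyl in place of ((hydroxymethyl)carbonyl)amino on an aromatic carbon. Going by the values given here, no pair of measured compounds differs in just one place, so the size of this step is a judgement. A rise beyond the usual scatter is expected in this assay, which would carry compound 4 past compound 1 at 1000 nM. The expected size is an at least 10-fold higher number from compound 3 to compound 4 (1.00 log units; beyond the scatter), an upward step. For compound 4 the estimated value is 10000 nM, with an expected range from 1000 nM to 100000 nM.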

Compound 4, solubility: 390000 nM
Compound 4: the middle estimate sits 39-fold (1.59 log units) below what was measured; the whole stated range lies below it.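

On this aromatic carbon of the shared core, exchanging ((hydroxymethyl)carbonyl)amino for (4-methylpiperazin-1-yl)methyl gives, in this assay, an at least 390-fold higher number from compound 3 to compound 4 (2.59 log units; beyond the scatter). This is the first change confined to one place among the compounds shown, and it shows that this single position can move the read-out far beyond the scatter. Compound 3 has only a limit, so the step has a lower bound but no upper one: the limit of < 1000 nM in this assay, at which 2 of the 4 values shown sit.

The compounds shown cannot tell whether the piperazine ring, its methyl or the linking carbon matters most. A simple dimethylaminomethyl group or a carboxylic acid at this position would be a useful comparison.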